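The source may report more compounds than this note shows. Statements on the series, on what has been measured and on what is new or still open speak of the compounds shown alone.

Measured so far:
- compound 1 `CCCCCCCCCCc1cc2cn(COCCO)c(O)nc-2n1`: 32000 nM
- compound 2 `CCCCCCC#Cc1cc2cn(COCCO)c(=O)nc2o1`: > 50000 nM

In a functional assay on HEL cells (Homo sapiens) (a lower number here means that less compound is tolerated, a higher number that more compound is tolerated), compound 2 gives > 50000 nM, which is a limit of the assay and not a number. Compound 2 therefore stands at the limit of > 50000 nM in this assay, at which 1 of the 2 values shown sits. Within the data shown here, compound 1 gives 32000 nM, the only exact number so far.

Compound 3 `CCCCCCCC#Cc1cc2cn(COCCO)c(=O)nc2o1` differs from compound 2 by one change: methyl in place of hydrogen on a saturated chain carbon, six bonds along the chain from a triple-bonded carbon. This places methyl in place of hydrogen on a saturated chain carbon, six bonds along the chain from a triple-bonded carbon. Among the measured compounds shown here, no measured pair isolates this change, so the expectation rests on the size of the change alone. The expected step of an at least 1.1-fold lower number from compound 2 to compound 3 (0.04 log units; that floor lies within the scatter) is small, with no change beyond the usual scatter of this assay. A limit reading is again quite possible. The estimated value for compound 3 is 45000 nM, with an expected range of 20000 nM to 90000 nM.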

Compound 3, half-maximal cytotoxic concentration: > 50000 nM
Compound 3: no number, only a limit (the forecaster's own chance of this, stated with the estimate: 55%); middle value at least 1.1-fold (0.04 log units) away from the limit.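

Compound 2 and compound 3 each give only a limit and not a number, so no step between them can be read: the limit of > 50000 nM in this assay, at which 2 of the 3 values shown sit.

Going by these compounds, whether methyl in place of hydrogen on this saturated chain carbon shifts the half-maximal cytotoxic concentration at all remains open.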